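The source may hold more compounds than are shown below. What is called first, only, known or untested is meant among the compounds shown, and "the series" means these compounds.

Compound 2, `Cc1cc(Br)c(Oc2nc(Nc3ccc(C#N)cc3)nc3ccccc23)c(Br)c1`, gives 25000 nM in an ADME assay on MT4 cells (Homo sapiens) for cytotoxicity, read by MTT assay, with a stated time of 4 days (on this read-out higher numbers stand for lower toxicity in this test and lower numbers for higher toxicity in this test), the lowest of the two numbers measured there. Its nearest neighbour is compound 3, `Cc1cc(C#N)cc(C)c1Oc1nc(Nc2ccc(C#N)cc2)nc2ccc(Cl)cc12`, which gives 117000 nM in this assay, a gap that lies beyond the scatter. Compound 1, `N#Cc1ccc(Nc2nc(Oc3ccc(F)cc3)c3ccccc3n2)cc1`, gives only a limit of this assay, > 351000 nM. That limit is recorded as the limit of > 351000 nM in this assay, at which 1 of the 3 values shown sits. Compound 4, `Cc1ccc(Oc2nc(Nc3ccc(C#N)cc3)nc3ccccc23)cc1`, has not yet been measured; it differs from compound 2 in one place: 4-methylphenyl in place of 2,6-dibromo-4-methylphenyl on an oxygen on an aromatic ring. For the measured compounds named here, the only measured step that bears on this position is an at least 14-fold lower number from compound 1 to compound 2 (1.14 log units; beyond the scatter), in which the 2,6-dibromo-4-methylphenyl entered and the number dropped from a limit to a measured value. In compound 4 the bromines leave again while the methyl stays, so the step is expected to run the other way, toward a higher number, though how much the 4-methylphenyl alone carries is not known from these compounds. Compound 4 is therefore estimated to give 150000 nM in this assay, within a range from 50000 nM to 400000 nM. The expected step is a 6.0-fold higher number from compound 2 to compound 4 (0.78 log units; beyond the scatter).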

Compound 4, half-maximal cytotoxic concentration: 87000 nM
For compound 4 the middle estimate is 1.7-fold (0.24 log units) above the measured one; low and high end bracket the measured number.
By their numbers in this assay, from the lowest: compound 2; then compounds 4 and 3 (each within the scatter of the next). At a limit, above all of these: compound 1.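

In this assay, taking the two bromines away while the methyl stays gives a 3.5-fold higher number from compound 2 to compound 4 (0.54 log units; beyond the scatter), so the bromines alone move the number at this position, with the 4-methylphenyl still in place. The exchange on the aromatic carbon, methyl in place of fluoro, also moves it, giving an at least 4.0-fold lower number from compound 1 to compound 4 (0.60 log units; beyond the scatter), which shows that the earlier large drop on entry of the 2,6-dibromo-4-methylphenyl was shared between the methyl and the bromines. The share of the methyl remains a bound, because compound 1 is recorded only as a limit: the limit of > 351000 nM in this assay, at which 1 of the 4 values shown sits.

As far as these compounds go, how a single bromine would compare with two, and where a methoxy or an amine in place of the methyl would fall, stays open. Compound 3 differs from these compounds in more than one place, so it settles neither question.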